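Ester to Acid on a Weak Oxadiazole Ketone

The compounds below may be only part of what the source reports. "The series", "measured", "known", "first", "only" and "open" are said of these compounds alone.

Compound 1 `O=C(CCc1ccc(-c2ccccc2)cc1)c1nnc(-c2cccc(Br)n2)o1` gives 3.6 nM.
Compound 2 `c1ccc(CCCCCCCc2nnc(-c3ccccn3)o2)cc1` gives 60000 nM.
Compound 3 `COC(=O)c1cccc(-c2nnc(CC(=O)Cc3ccc(-c4ccccc4)cc3)o2)n1` gives only a limit, > 2500 nM.

In an assay for inhibition of Fatty-acid amide hydrolase 1 (Rattus norvegicus) (on this read-out higher numbers stand for weaker inhibition and lower numbers for stronger inhibition), three compounds have been measured. Compound 3 sits at a limit rather than at a number: the limit of > 2500 nM in this assay, at which 1 of the 3 values shown sits, marks where it stands, and nothing more precise is known for it. The next compound, compound 4 `O=C(Cc1ccc(-c2ccccc2)cc1)Cc1nnc(-c2cccc(C(=O)O)n2)o1`, differs from compound 3 by hydrogen in place of methyl on an oxygen next to a carbonyl group. For the measured compounds named here, no measured pair of compounds shows this change, so there is no measured step to lean on. Compound 4 is expected to remain a weak inhibitor, with an estimated step that the limit leaves unreadable from compound 3 to compound 4 that need not exceed the usual scatter. The estimate for compound 4 is 6000 nM, within a range of 1500 nM to 40000 nM.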

Compound 4, inhibition constant: > 2500 nM
Compound 4 was reported as a limit; the forecaster's own chance of this, stated with the estimate: 50%; the middle value is on the limit's open side.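

Compound 3 and compound 4 both stand only at a limit, so no step can be read between them: the limit of > 2500 nM in this assay, at which 2 of the 4 values shown sit.

As far as these compounds go, how far methoxycarbonyl to carboxy shifts inhibition in this assay stays open, as does the true value of either compound.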